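Amide variation in a bis-sulfonyl piperidine series

This account rests on a few compounds, and the source may have more. Where it says the series, first, only, none or still open, it means among the compounds named here.

Measured so far in a functional assay on MIA PaCa-2 cells (Homo sapiens) for inhibition, read by MTT assay, with a stated time of 7 days; a higher number here means a weaker inhibitor, a lower number a stronger inhibitor:
compound 1 `CCC(CC)S(=O)(=O)c1ccc(S(=O)(=O)N2CCC[C@@H](C(=O)N3CCC(F)(F)CC3)C2)cc1`, 13 nM
compound 2 `O=C([C@@H]1CCCN(S(=O)(=O)c2ccc(S(=O)(=O)C3COC3)cc2)C1)N1CCC(F)(F)CC1`, 110 nM
compound 3 `CCN(CC)S(=O)(=O)c1ccc(S(=O)(=O)N2CCC[C@@H](C(=O)NC3CCOCC3)C2)cc1`, 3770 nM

Compound 3 gives the highest number of the three, beyond the scatter from both compound 2 and compound 1. Compound 4 `CCN(CC)S(=O)(=O)c1ccc(S(=O)(=O)N2CCC[C@@H](C(=O)N3CCC(C(F)F)CC3)C2)cc1` differs from compound 3 at the amide: 4-(difluoromethyl)piperidin-1-yl in place of (oxan-4-yl)amino on a carbonyl carbon. Among the measured compounds shown here, no measured step changes the carbonyl substituent alone; the only step, an 8.5-fold higher number from compound 1 to compound 2 (0.93 log units; beyond the scatter), concerns the sulfonyl sulfur and does not bear directly on this change. Compounds 1 and 2, which carry a cyclic amide, both give far lower numbers than compound 3, but they also differ at the sulfonyl group, so the two changes cannot be separated. A lower number is expected for compound 4, with wide uncertainty, a 9.4-fold lower number from compound 3 to compound 4 (0.97 log units; beyond the scatter). Compound 4 is estimated at 400 nM, between 80 nM and 2000 nM.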

Compound 4, half-maximal inhibitory concentration: 420 nM
For compound 4 the middle estimate is 1.1-fold (0.02 log units) below the measured one, and the stated range covers the measured number.
By their numbers in this assay, from the lowest: compound 1; then compound 2; then compound 4; then compound 3.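

In this assay the carbonyl substituent now has its first isolated step: 4-(difluoromethyl)piperidin-1-yl in place of (oxan-4-yl)amino gives a 9.0-fold lower number from compound 3 to compound 4 (0.95 log units; beyond the scatter) with the rest of the molecule unchanged. This position therefore affects the read-out independently of the sulfonyl group. No measurement shown explains the step.

The change alters the ring, the fluorine content and the donor count together, and these contributions remain unseparated. A plain piperidin-1-yl on the same carbonyl carbon would help divide them.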